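Swapping bromo for chloro on a catechol cinnamate ester

This account rests on a few compounds, and the source may have more. Where it says the series, first, only, none or still open, it means among the compounds named here.

Measured compounds:
- compound 1 `O=C(/C=C/c1cc(O)c(O)c([N+](=O)[O-])c1)OCCc1ccccc1`: "not determined" (no result reported)
- compound 2 `CC1(C)C2CCC1(C)C(OC(=O)/C=C/c1cc(O)c(O)c(Br)c1)C2`: "not determined" (no result reported)
- compound 3 `O=C(/C=C/c1cc(O)c(O)c(Cl)c1)OCCc1ccccc1`: 8180 nM

Three compounds share a catechol-bearing cinnamate ester core and differ in the ester alcohol and in the group on the aromatic ring. In a functional assay on SGC-7901 cells (Homo sapiens) for inhibition, read by MTT assay (on this read-out higher numbers stand for weaker inhibition and lower numbers for stronger inhibition), compound 3 gives 8180 nM. For compound 2 the entry in this assay reads "not determined" (no result reported), so compound 2 stands without a single number, and one further entry, that of compound 1, likewise has no single number. The only numerical anchor is therefore compound 3.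

The next compound, compound 4 `CC1(C)C2CCC1(C)C(OC(=O)/C=C/c1cc(O)c(O)c(Cl)c1)C2`, keeps the bicyclic ester of compound 2 and changes one group: chloro in place of bromo on an aromatic carbon. Going by the values given here, because compound 2 has no value, no step can be computed, and nothing among the measured compounds isolates this exchange. Chloro and bromo are both single halogen atoms, so the step from compound 2 to compound 4 in this assay is expected to be small, within the scatter, in no particular direction.

Resting on compound 3 with 8180 nM as the nearest measured chloro compound, compound 4 is estimated at 8000 nM, with a range from 2500 nM to 25000 nM.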

Compound 4, half-maximal inhibitory concentration: 69500 nM
The estimate for compound 4 lay 8.7-fold (0.94 log units) below the measured number; measured number outside the range, above it.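

In this assay, going by these compounds alone, compound 2 carries no single number, so no step from it to compound 4 can be read. The compounds shown leave open how exchanging bromo for chloro on this core changes inhibition. No supporting evidence bears on this result.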